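Shifting the methylindole attachment in the series

The source may hold more compounds than are shown below. What is called first, only, known or untested is meant among the compounds shown, and "the series" means these compounds.

In a functional assay on B16-F0 cells (Mus musculus) for inhibition, read by CCK-8 assay, with a stated time of 48 h (on this read-out lower numbers stand for stronger inhibition and higher numbers for weaker inhibition), compound 1 `COc1cc(-c2ccnc3cc(-c4c[nH]c5ccccc45)nn23)cc(OC)c1OC` gives 40 nM and compound 2 `COc1cc(-c2ccnc3cc(-c4ccc5c(ccn5C)c4)nn23)cc(OC)c1OC` gives 48 nM, so compound 2 stands level with compound 1 within the scatter. Compound 3 `COc1cc(-c2ccnc3cc(-c4ccc5ccn(C)c5c4)nn23)cc(OC)c1OC` carries 1-methyl-1H-indol-6-yl in place of 1-methyl-1H-indol-5-yl on an aromatic carbon. Going by the values given here, the one measured step, a 1.2-fold higher number from compound 1 to compound 2 (0.08 log units; within the scatter), also changes where the indole is attached and stays within the scatter. It is a single step, so it is weak guidance. The expected change is a 1.3-fold higher number from compound 2 to compound 3 (0.10 log units; within the scatter), with no step beyond the scatter anticipated in this assay. Compound 3 is estimated at 60 nM, with an expected range of 20 nM to 200 nM.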

Compound 3, half-maximal inhibitory concentration: 657 nM
The estimate for compound 3 lay 11-fold (1.04 log units) below the measured number; measured number above the stated range.
By their numbers in this assay, from the lowest: compounds 1 and 2 (each within the scatter of the next); then compound 3.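

In this assay, the step from 1-methyl-1H-indol-5-yl to 1-methyl-1H-indol-6-yl is a 14-fold higher number from compound 2 to compound 3 (1.14 log units; beyond the scatter), although both groups have the same atoms, so at this position the point of attachment alone can decide the number. Against the 1H-indol-3-yl group the change is a 16-fold higher number from compound 1 to compound 3 (1.22 log units; beyond the scatter), so a change of indole attachment is not neutral here, even though compounds 1 and 2 stand level within the scatter. Nothing available accounts for this difference.

Open, going by these compounds, is whether 1H-indol-6-yl, without the methyl, behaves like 1-methyl-1H-indol-6-yl. Also open, on these data alone, is where a 1-methyl-1H-indol-4-yl group would fall.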